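The source may hold more compounds than are shown below. What is called first, only, known or untested is meant among the compounds shown, and "the series" means these compounds.

Measured so far in an ADME assay on MOLT-3 cells (Homo sapiens) for cytotoxicity, with a stated time of 7 days; a higher number here means that more compound is tolerated, a lower number that less compound is tolerated:
- compound 1, `CNc1nc(N)nc2c1ncn2/C=C1/CC1(CO)CO`: > 20000 nM
- compound 2, `C=CCOc1nc(N)nc2c1ncn2/C=C1/CC1(CO)CO`: > 20000 nM

Compound 1 gives > 20000 nM in this assay, which is a limit of the assay and not a number. Compound 2 likewise gives > 20000 nM in this assay, again only a limit. The one measured step, a step that the two limits leave unreadable from compound 1 to compound 2, is therefore unreadable in size; both values sit at the limit of > 20000 nM in this assay, at which 2 of the 2 values shown sit, so compound 2 stands at the tolerated end of what is shown, with nothing finer known.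

Compound 3, `Nc1nc(NC2CC2)c2ncn(/C=C3/CC3(CO)CO)c2n1`, differs from compound 2 by cyclopropylamino in place of allyloxy on an aromatic carbon. Among the measured compounds shown here, no measured step bears directly on this exchange, and the only step, a step that the two limits leave unreadable from compound 1 to compound 2, carries no readable size. For the measured compounds named here, both compounds measured so far were tolerated up to the limit, so no change beyond the scatter is expected in this assay for the exchange at hand. Compound 3 is therefore expected at about 25000 nM, with a range from 10000 nM to 60000 nM, most likely reported as a limit. The step that the limit leaves unreadable from compound 2 to compound 3 is expected to be none beyond the scatter.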

Compound 3, half-maximal cytotoxic concentration: > 20000 nM
Compound 3: no number, only a limit (the forecaster's own chance of this, stated with the estimate: 80%); the middle value is on the limit's open side.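

In this assay compound 3 gives > 20000 nM, a limit of the assay and not a number. No size can be read for the new steps linking compound 3 with compound 1 and compound 2: the limit of > 20000 nM in this assay, at which 3 of the 3 values shown sit.

The compounds shown leave open the concentration at which compound 1, compound 2 or compound 3 reaches half-maximal cytotoxicity, and whether their substituents differ in this read-out.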